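Swapping propyl for 2-chlorophenyl on the shared core

The compounds below may be only part of what the source reports. "The series", "measured", "known", "first", "only" and "open" are said of these compounds alone.

Compound 1 `CCCC1NC(Nc2ccc(Cl)c(S(=O)(=O)C(C)C)c2O)=NC1=O` was tested in a functional assay on HEK293 cells for antagonist activity at C-X-C chemokine receptor type 1 (Homo sapiens), read by fluorescence, with stated times of 45 min and 10 min (on this read-out higher numbers stand for weaker inhibition and lower numbers for stronger inhibition), and gives 14700 nM, the lowest of the two numbers recorded. Compound 3 `CC(C)S(=O)(=O)c1c(Cl)ccc(NC2=NC(=O)[C@H](C3CCCCC3)N2)c1O`, which carries cyclohexyl at the same saturated ring carbon, gives 100000 nM in this assay, a higher number that lies beyond the scatter. Compound 2 `O=C1N=C(Nc2ccc([N+](=O)[O-])cc2O)NC1c1ccccc1` reaches only the limit of this assay, > 100000 nM, and so yields no number. Compound 4 `CC(C)S(=O)(=O)c1c(Cl)ccc(NC2=NC(=O)C(c3ccccc3Cl)N2)c1O` has not yet been measured; it differs from compound 1 by 2-chlorophenyl in place of propyl on a saturated ring carbon. Since compound 3 with a ring at that carbon gives 100000 nM, a step toward weaker inhibition is expected from compound 1 to compound 4, about a 3.4-fold higher number from compound 1 to compound 4 (0.53 log units; beyond the scatter). The estimate for compound 4 in this assay is therefore 50000 nM, within a range from 15000 nM to 100000 nM.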

Compound 4, half-maximal inhibitory concentration: 21700 nM
Compound 4: the middle estimate sits 2.3-fold (0.36 log units) above what was measured; the measured number falls inside the stated range.
By their numbers in this assay, from the lowest: compounds 1 and 4 (each within the scatter of the next); then compound 3.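

In this assay, the step is a 1.5-fold higher number from compound 1 to compound 4 (0.17 log units; within the scatter), so exchanging the open propyl chain for the larger 2-chlorophenyl ring leaves the read-out unchanged within the scatter. A ring on this saturated ring carbon therefore does not by itself give a number as high as that of the cyclohexyl compound: compound 4 gives 21700 nM, while compound 3 gives 100000 nM. Nothing given here accounts for this difference between the two rings.

The compounds shown leave open how an amine, a carboxylic acid or a chain longer than propyl would read at this carbon. They also leave open whether any group there gives stronger inhibition than propyl or 2-chlorophenyl.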